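Tert-butoxycarbonyl in place of chloro on the azole ring

The source may hold more compounds than are shown below. What is called first, only, known or untested is meant among the compounds shown, and "the series" means these compounds.

Measured so far:
Compound 1, `O=Cc1cn(C[C@H]2CN(c3ccc(C4=CCS(=O)(=O)CC4)c(F)c3)C(=O)O2)nn1`: in an assay for binding affinity to Amine oxidase [flavin-containing] A (Homo sapiens) (a higher number here means a weaker inhibitor, a lower number a stronger inhibitor), compound 1 gives 3200 nM.
Compound 2, `O=C1O[C@@H](Cn2cc(Cl)nn2)CN1c1ccc(C2=CCS(=O)(=O)CC2)c(F)c1`: in this assay compound 2 gives 3000 nM.
Compound 3, `C#Cc1cn(C[C@H]2CN(c3ccc(C4=CCS(=O)(=O)CC4)c(F)c3)C(=O)O2)nn1`: in this assay compound 3 reaches only a limit, > 200000 nM.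

Compound 2 stands at the lowest of the two numbers, with compound 1 nearest; the two lie within the scatter of each other, as the step of a 1.1-fold lower number from compound 1 to compound 2 (0.03 log units; within the scatter) shows. Compound 3 sits at the limit (the limit of > 200000 nM in this assay, at which 1 of the 3 values shown sits).

Compound 4, `CC(C)(C)OC(=O)c1cn(C[C@H]2CN(c3ccc(C4=CCS(=O)(=O)CC4)c(F)c3)C(=O)O2)nn1`, differs from compound 2 in one place: tert-butoxycarbonyl in place of chloro on an aromatic carbon. Within the data shown here, no measured step carries this exact change. Among the measured compounds shown here, two steps bear on the position. Chloro and formyl are interchangeable within the scatter, a 1.1-fold lower number from compound 1 to compound 2 (0.03 log units; within the scatter). Ethynyl at the same position costs a large amount, an at least 66-fold higher number from compound 2 to compound 3 (1.82 log units; beyond the scatter) and an at least 62-fold higher number from compound 1 to compound 3 (1.79 log units; beyond the scatter). The tert-butoxycarbonyl group is neither of the tolerated pair and brings far more heavy atoms than ethynyl, so a loss is expected; its size is uncertain, and a limit is a real possibility. The expected step is a 5.0-fold higher number from compound 2 to compound 4 (0.70 log units; beyond the scatter). Compound 4 is estimated at 15000 nM in this assay, within the range 2500 nM to 120000 nM.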

Compound 4, inhibition constant: 3500 nM
For compound 4 the middle estimate is 4.3-fold (0.63 log units) above the measured one, within the range that was stated.
By their numbers in this assay, from the lowest: compounds 2, 1 and 4 (each within the scatter of the next). At a limit, above all of these: compound 3.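

In this assay, the aromatic carbon of the five-membered aromatic ring with 3 nitrogen accepts tert-butoxycarbonyl, with 7 heavy atoms, in place of chloro, with 1 heavy atom, without a change beyond the scatter: a 1.2-fold higher number from compound 2 to compound 4 (0.07 log units; within the scatter) shows that this larger group carries no measurable cost here. Tert-butoxy in place of hydrogen on the carbonyl carbon of the formyl group is just as silent, a 1.1-fold higher number from compound 1 to compound 4 (0.04 log units; within the scatter), so compounds 1, 2 and 4 now form a set of three different groups that lie within the scatter of one another. Ethynyl alone stands apart from this set among the groups shown, an at least 57-fold lower number from compound 3 to compound 4 (1.75 log units; beyond the scatter), and the value of compound 3 is a limit: the limit of > 200000 nM in this assay, at which 1 of the 4 values shown sits.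

As far as these compounds go, whether an amine or a carboxylic acid on this carbon would stay with compounds 1, 2 and 4 or fall with compound 3 remains open. What sets ethynyl apart also remains open: a nitrile or a longer alkyne on the same carbon would bear on that question, and the values shown give no cause.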